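Thiophen-3-yl for furan-2-yl on the shared core

The source may report more compounds than this note shows. Statements on the series, on what has been measured and on what is new or still open speak of the compounds shown alone.

Of the compounds shown here, two have numbers so far in an ADME assay on HeLa cells (Homo sapiens) for cytotoxicity, read by resazurin assay, with a stated time of 2 days (on this read-out lower numbers stand for stronger inhibition and higher numbers for weaker inhibition), and both sit close together. Compound 1 (`Cn1c([N+](=O)[O-])cnc1/C=C/c1ccc(OC(F)(F)F)cc1`) gives 83200 nM and compound 2 (`Cn1c([N+](=O)[O-])cnc1/C=C/c1ccco1`) gives 93300 nM on the same read-out. Compound 2 thus stands within the usual scatter of compound 1, and the two cannot be told apart.

Compound 3 (`Cn1c([N+](=O)[O-])cnc1/C=C/c1ccsc1`) awaits measurement. It keeps the core of compound 2 and carries thiophen-3-yl in place of furan-2-yl on a double-bonded chain carbon bound to a double-bonded chain carbon. Going by the values given here, no measured pair yet isolates a single change, so the data offer no direct guide to this swap. Among the compounds with values here, the only hint is that compound 1 at 83200 nM and compound 2 at 93300 nM carry different groups at that place and still lie within the scatter. No step beyond the scatter, in either direction, is therefore expected in this assay here. The estimate amounts to a step of a 1.1-fold lower number from compound 2 to compound 3 (0.04 log units; within the scatter) that is expected to stay within the scatter. For compound 3 the estimated value is 85000 nM with 42000 nM to 160000 nM as the expected range.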

Compound 3, half-maximal inhibitory concentration: > 100000 nM
Compound 3 ended at the assay's limit; the forecaster's own chance of this, stated with the estimate: 20%; middle value at least 1.1-fold (0.07 log units) from the limit.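

Thiophen-3-yl in place of furan-2-yl on a double-bonded chain carbon bound to a double-bonded chain carbon gives the first single change that can be read in this assay, and it amounts to an at least 1.0-fold higher number from compound 2 to compound 3 (0.03 log units; that floor lies within the scatter). The value of compound 3, > 100000 nM, is a limit of the assay and not a number, so the step has a floor and no known size, and a true gap of any width may lie behind it. The exchange keeps the heavy atom count and the single five-membered aromatic ring with 1 hetero atom, putting sulfur for oxygen, yet the reading can go no further than the edge of what the assay reports, the only reading of this kind so far: the limit of > 100000 nM in this assay, at which 1 of the 3 values shown sits.

The compounds shown leave open whether any group at this place can move the number beyond the scatter in this assay, for instance a phenyl ring carrying an amine or a carboxylic acid, or a longer chain in place of the ring. They also leave open what a change on the shared core would do, such as a nitrile in place of the nitro group.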